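This account rests on a few compounds, and the source may have more. Where it says the series, first, only, none or still open, it means among the compounds named here.

Among the measured compounds shown here, compound 3 `COc1cc(Oc2cccc(Nc3ccccc3)c2)cc(OC)c1CNCCNC(C)=O` gives 5090 nM in a functional assay on HCT-15 cells (Homo sapiens) for inhibition, read by MTT assay, with a stated time of 72 h (a lower number here means a stronger inhibitor, a higher number a weaker inhibitor), the highest of the three numbers measured so far. Compound 1 `COc1cc(Oc2cccc(Nc3ccccc3)c2)cc(OC)c1CNCc1ccccc1` gives 5020 nM in this assay. The step of a 1.0-fold higher number from compound 1 to compound 3 (0.01 log units; within the scatter) lies within the scatter. Compound 2 `COc1ccc(CCCNCc2c(OC)cc(Oc3ccc(Nc4ccccc4)cc3)cc2OC)cc1` gives 2180 nM, the lowest of the three. The unmeasured compound 4 `COc1ccc(CCCNCc2c(OC)cc(Oc3cccc(Nc4ccccc4)c3)cc2OC)cc1` differs from compound 3 by 4-methoxybenzyl in place of acetamido on a saturated chain carbon, two bonds along the chain from an amine nitrogen. For the measured compounds named here, the only measured step at the amine substituent, a 1.0-fold higher number from compound 1 to compound 3 (0.01 log units; within the scatter), changed nothing beyond the scatter. Going by the values given here, compound 2 carries the same 3-(4-methoxyphenyl)propyl chain as compound 4 and sits below compound 3, but no single-change step connects those two. Compound 4 is therefore expected to land between those two numbers, a modest expected step of a 1.7-fold lower number from compound 3 to compound 4 (0.23 log units; within the scatter) toward a lower number. The estimate for compound 4 is 3000 nM, with a range from 1200 nM to 7500 nM.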

Compound 4, half-maximal inhibitory concentration: 730 nM
Compound 4: the middle estimate sits 4.1-fold (0.61 log units) above what was measured; the measured number lies below the stated range.
By their numbers in this assay, from the lowest: compound 4; then compound 2; then compounds 1 and 3 (each within the scatter of the next).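

In this assay, the amine substituent turns out to be able to move the number: the 3-(4-methoxyphenyl)propyl chain brings a 7.0-fold lower number from compound 3 to compound 4 (0.84 log units; beyond the scatter) and a 6.9-fold lower number from compound 1 to compound 4 (0.84 log units; beyond the scatter), whereas a 1.0-fold higher number from compound 1 to compound 3 (0.01 log units; within the scatter) had changed nothing beyond the scatter. Of the three amine substituents on this shared core, only this chain separates from the others. Nothing available explains this result. Going by these compounds, whether the change belongs to the methoxy group or to the length of the chain stays open, and a 3-phenylpropyl chain on the same amine would separate the two.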